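Adding a methoxy group: prospective note on compound 3

The source may report more compounds than this note shows. Statements on the series, on what has been measured and on what is new or still open speak of the compounds shown alone.

Measured so far:
compound 1: `Nc1cc(N)c2nc(-c3ccccc3)c(NCc3ccc(Cl)c(Cl)c3)nc2c1` — in a functional assay on U-251 cells (Homo sapiens) for inhibition, read by sulforhodamine B assay, with a stated time of 48 h (a higher number here means that more compound is tolerated, a lower number that less compound is tolerated), a limit, < 100000 nM
compound 2: `COc1ccc(CNc2nc3cc(N)cc(N)c3nc2-c2ccccc2)cc1OC` — in this assay 89100 nM

Going by the values given here, compound 2 holds the only number in this assay; the other value shown is a limit. Among the compounds with values here, the single measured step, a step that the limit leaves unreadable from compound 1 to compound 2, cannot be sized because of the limit of < 100000 nM in this assay, at which 1 of the 2 values shown sits, so it gives no readable guide.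

Compound 3, `COc1cc(CNc2nc3cc(N)cc(N)c3nc2-c2ccccc2)cc(OC)c1OC`, differs from compound 2 by methoxy in place of hydrogen on an aromatic carbon. Within the data shown here, no measured step concerns the addition of a methoxy group, and the one step that exists is left unreadable by the limit. With nothing pointing either way, the expected step of a 1.0-fold higher number from compound 2 to compound 3 (0.00 log units; within the scatter) is estimated to lie within the scatter, in no direction. Compound 3 is therefore expected to give about 90000 nM in this assay, estimated between 45000 nM and 180000 nM, with a real chance that only a limit is reported.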

Compound 3, concentration lethal to 50% of the cells: 30200 nM
Compound 3: middle estimate off by 3.0-fold (0.47 log units), on the high side; the measured number lies below the stated range.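

Methoxy in place of hydrogen on this aromatic carbon, ortho to a methoxy group and meta to a large group, gives the first readable step in the series: a 3.0-fold lower number from compound 2 to compound 3 (0.47 log units; beyond the scatter). In this assay, this single addition therefore moves the number beyond the scatter, towards less compound tolerated, so this position is not silent. That rests on one pair of compounds, since the step from compound 1 to compound 2 cannot be read: the limit of < 100000 nM in this assay, at which 1 of the 3 values shown sits.

The compounds shown leave open whether this shift is specific to methoxy or would also appear with a hydroxyl, a fluorine or a longer alkoxy chain on the same carbon. Also open, going by these compounds, is whether the same addition would give a step of this size on the 3,4-dichlorophenyl of compound 1.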